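This account rests on a few compounds, and the source may have more. Where it says the series, first, only, none or still open, it means among the compounds named here.

Compound 1 `Cc1ccc([C@@]2(CO)NC[C@H](O)[C@H]2O)cc1` gives 17000 nM in an assay on isolated protein for inhibition of lysosomal alpha-glucosidase (Rattus norvegicus), read by colorimetric assay (on this read-out lower numbers stand for stronger inhibition and higher numbers for weaker inhibition), the lowest of the three numbers shown. For the measured compounds named here, its mirror image, compound 3 `Cc1ccc([C@]2(CO)NC[C@@H](O)[C@@H]2O)cc1`, gives 43000 nM in this assay, and the step of a 2.5-fold higher number from compound 1 to compound 3 (0.40 log units; beyond the scatter) is the only one-place change measured so far. Compound 2 `OC[C@]1(c2c(F)c(F)c(F)c(F)c2F)NC[C@H](O)[C@H]1O` gives 183000 nM and differs from compound 1 in more than one place, so its values are shown only for comparison.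

Compound 4 `OC[C@]1(c2ccc(O)cc2)NC[C@H](O)[C@H]1O` differs from compound 1 by hydroxy in place of methyl on an aromatic carbon. Going by the values given here, no measured step changes a substituent on the aromatic ring, so nothing measured bears directly on this change, and no step beyond the scatter is expected in this assay. For compound 4 the expected step is a 1.2-fold higher number from compound 1 to compound 4 (0.07 log units; within the scatter), giving an estimated 20000 nM with a range from 6000 nM to 70000 nM.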

Compound 4, half-maximal inhibitory concentration: 2600 nM
Beside the measured number, compound 4's estimate is 7.7-fold (0.89 log units) above it; the measured number lies below the stated range.
By their numbers in this assay, from the lowest: compound 4; then compound 1; then compound 3; then compound 2.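

In this assay, the aromatic ring turns out to be a place where a small change counts: hydroxy in place of methyl on that aromatic carbon gives a 6.5-fold lower number from compound 1 to compound 4 (0.82 log units; beyond the scatter). For the compounds shown here, this is the first measured step on a ring substituent, and it shows that the swap of a single heavy atom can move the number while the core stays the same. Nothing measured here explains the gain.

From the compounds shown here alone, whether it is specific to hydroxy stays open, since methoxy, an amine or a carboxylic acid on the same carbon would test that. Going by these compounds, how the mirror image of compound 4 compares also remains open.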